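The source may report more compounds than this note shows. Statements on the series, on what has been measured and on what is new or still open speak of the compounds shown alone.

Measured in a functional assay on MDA-MB-468 cells (Homo sapiens) for antiproliferative activity, read by sulforhodamine B assay, with a stated time of 4 days; on this read-out higher numbers stand for weaker inhibition of growth and lower numbers for stronger inhibition of growth:
- compound 1 `COc1cc(Cl)c(-c2nc(SCC(=O)NC(C)C)nc3[nH]cc(C#N)c23)cc1O`: 178 nM
- compound 2 `COc1cc(Cl)c(-c2nc(SCC(=O)NC(C)(C)C)nc3[nH]cc(C#N)c23)cc1O`: 152 nM

In this assay compound 2 gives 152 nM, within the scatter of compound 1 at 178 nM. Compound 3 `COc1cc(Cl)c(-c2nc(SCC(=O)N3CCC3)nc3[nH]cc(C#N)c23)cc1O` differs from compound 2 as follows: azetidin-1-yl in place of (tert-butyl)amino on a carbonyl carbon. Going by the values given here, the only measured step bearing on this, a 1.2-fold lower number from compound 1 to compound 2 (0.07 log units; within the scatter), changes the same amide substituent but keeps the amide hydrogen, so it is a weak guide. Among the compounds with values here, no measured compound has the ring, and no clear step beyond the scatter is expected. The estimated step is a 1.3-fold higher number from compound 2 to compound 3 (0.12 log units; within the scatter). For compound 3 the expected value is 200 nM, with an estimated range of 70 nM to 550 nM.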

Compound 3, concentration for 50% growth inhibition: 28 nM
For compound 3 the middle estimate is 7.1-fold (0.85 log units) above the measured one; the measured number lies below the stated range.
By their numbers in this assay, from the lowest: compound 3; then compounds 2 and 1 (each within the scatter of the next).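

In this assay azetidin-1-yl on the carbonyl carbon gives a 5.4-fold lower number from compound 2 to compound 3 (0.73 log units; beyond the scatter) and a 6.4-fold lower number from compound 1 to compound 3 (0.80 log units; beyond the scatter) against the two open-chain amides. The earlier change at this position, a 1.2-fold lower number from compound 1 to compound 2 (0.07 log units; within the scatter) stayed within the scatter, so this amide substituent proved able to move the number only with the ring in place and the amide hydrogen gone. No measurement at hand explains the step.

On these data alone, whether the ring or the loss of the amide hydrogen carries the step remains open. Dimethylamino and pyrrolidin-1-yl on the same carbonyl carbon would bear on both that question and the effect of ring size.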